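Fluorine position on the distal phenyl: compound 3

The source may hold more compounds than are shown below. What is called first, only, known or untested is meant among the compounds shown, and "the series" means these compounds.

Measured in a functional assay for agonist activity at G protein-coupled receptor 88 (Homo sapiens), read by HTRF and cAMP accumulation (a higher number here means that more compound is needed for the effect, a lower number that less compound is needed), so far: compound 1 `COc1ccccc1-c1ccc(N(C[C@@H](N)CC(C)C)C(=O)[C@@H]2C[C@H]2c2ccccc2)cc1` gives 3200 nM, and compound 2 `CC(C)C[C@H](N)CN(C(=O)[C@@H]1C[C@H]1c1ccccc1)c1ccc(-c2cccc(F)c2)cc1` gives 2100 nM.

Compound 2 has the lower of the two numbers, but only by a 1.5-fold lower number from compound 1 to compound 2 (0.18 log units; within the scatter), so the two stand level. Compound 3 `CC(C)C[C@H](N)CN(C(=O)[C@@H]1C[C@H]1c1ccccc1)c1ccc(-c2ccccc2F)cc1` differs from compound 2 by 2-fluorophenyl in place of 3-fluorophenyl on an aromatic carbon. Going by the values given here, the single measured step, a 1.5-fold lower number from compound 1 to compound 2 (0.18 log units; within the scatter), swapped the whole distal aryl group and stayed within the scatter; no measured step moves fluorine around that ring. Compound 3 is therefore expected to show a 1.2-fold higher number from compound 2 to compound 3 (0.08 log units; within the scatter), nothing beyond the scatter. The estimate for compound 3 is 2500 nM, between 900 nM and 7000 nM.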

Compound 3, half-maximal effective concentration: 1600 nM
Estimate against measurement, compound 3: 1.6-fold (0.19 log units) above; low and high end bracket the measured number.
By their numbers in this assay, from the lowest: compounds 3, 2 and 1 (each within the scatter of the next).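

In this assay, 2-fluorophenyl in place of 3-fluorophenyl leaves the two compounds level (a 1.3-fold lower number from compound 2 to compound 3 (0.12 log units; within the scatter)), so the fluorine's place on this ring does not separate them. Fluoro in place of methoxy also stays level (a 2.0-fold lower number from compound 1 to compound 3 (0.30 log units; within the scatter)), which puts all three compounds within the scatter of one another at this position. Nothing on hand bears on what lies behind these numbers.

Still open, from the compounds shown here alone, is whether any group on this ring moves the number beyond the scatter. A nitrile, trifluoromethyl, an amine or a carboxylic acid there would test this.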